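Replacing the Carboxybutyl Arm with Isopropyl on the Amine

The source may hold more compounds than are shown below. What is called first, only, known or untested is meant among the compounds shown, and "the series" means these compounds.

Compound 2 has the structure `Nc1ncnc2c1ncn2[C@@H]1O[C@H](CN(CCCCC(=O)O)Cc2cccc(C(=O)O)c2)[C@@H](O)[C@H]1O`. In an assay on cells for inhibition of Nicotinamide N-methyltransferase (Homo sapiens), with stated times of 10 min and 30 min (on this read-out higher numbers stand for weaker inhibition and lower numbers for stronger inhibition), compound 2 gives only a limit of the assay, > 250000 nM. Its closest measured relative, compound 1 with the structure `NC(=O)CCCCN(Cc1cccc(C(=O)O)c1)C[C@H]1O[C@@H](n2cnc3c(N)ncnc32)[C@H](O)[C@@H]1O`, likewise reaches only a limit. In this assay compound 1 gives > 250000 nM. Among the measured compounds shown here, the single measured step, a step that the two limits leave unreadable from compound 1 to compound 2, is therefore of unreadable size, since both of its ends are limits; this is summarised by the limit of > 250000 nM in this assay, at which 2 of the 2 values shown sit.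

Compound 3, with the structure `CC(C)N(Cc1cccc(C(=O)O)c1)C[C@H]1O[C@@H](n2cnc3c(N)ncnc32)[C@H](O)[C@@H]1O`, has not yet been measured. It differs from compound 2 by isopropyl in place of 4-carboxybutyl on an amine nitrogen. For the measured compounds named here, no measured step bears on this change: the one recorded step concerns a different position and its size cannot be read. Going by the values given here, the two measured compounds therefore give no direction for the step to be expected, and the only thing the numbers show is that both of them sit at the limit.

Compound 3 is expected to give 50000 nM in this assay, within a range of 5000 nM to 250000 nM, and the estimated step is an at least 5.0-fold lower number from compound 2 to compound 3 (0.69 log units; beyond the scatter).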

Compound 3, half-maximal inhibitory concentration: > 250000 nM
Compound 3 was reported as a limit; the forecaster's own chance of this, stated with the estimate: 50%; at least 5.0-fold (0.69 log units) between middle value and limit.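

In this assay, among the compounds shown here, compound 3 also gives only a limit, so the steps joining it to compound 1 and compound 2 cannot be read, and no new step follows from this result: the limit of > 250000 nM in this assay, at which 3 of the 3 values shown sit. The compounds shown leave open what the actual value of any of the three is, and whether a change on the amine nitrogen alters inhibition at all.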